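A Methyl for Chloro on the Benzyl Group

This account rests on a few compounds, and the source may have more. Where it says the series, first, only, none or still open, it means among the compounds named here.

Values measured so far in a functional assay on RS4-11 cells (Homo sapiens) for inhibition, read by CCK-8 assay, with a stated time of 48 h, tested at 20 uM (on this read-out lower numbers stand for less inhibition of growth and higher numbers for more inhibition of growth at the one concentration tested), are these:
compound 1 `N#C/C(=C\c1ccccc1OS(=O)(=O)c1ccc(Cl)cc1)C(=O)Nc1nnc(Cc2ccccc2)s1` gives 73%
compound 2 `COc1ccc(S(=O)(=O)Oc2ccccc2/C=C(\C#N)C(=O)Nc2nnc(Cc3ccc(Cl)cc3)s2)cc1` gives 77%
compound 3 `N#C/C(=C\c1ccccc1OS(=O)(=O)c1ccc(Cl)cc1)C(=O)Nc1nnc(Cc2ccc(Cl)cc2)s1` gives 64%

Compound 3 (64%) has the lowest number of the three, yet it lies within the scatter of compound 1 and beyond the scatter only against compound 2. Compound 4 `Cc1ccc(Cc2nnc(NC(=O)/C(C#N)=C/c3ccccc3OS(=O)(=O)c3ccc(Cl)cc3)s2)cc1` departs from compound 3 at one place, methyl in place of chloro on an aromatic carbon with methyl in place of chloro on an aromatic carbon, para to a large group. This turns 4-chlorobenzyl into 4-methylbenzyl.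

Going by the values given here, two measured steps bear on this change. The closer one is a number 9 percentage points lower from compound 1 to compound 3 (within the scatter) and it puts chloro in place of hydrogen on the same aromatic carbon. The other is a number 13 percentage points lower from compound 2 to compound 3 (beyond the scatter) and it puts chloro in place of methoxy at a different aromatic carbon, so it says less about this change. Among the compounds with values here, no measured compound yet carries the methyl group, and the estimate rests on those two steps alone. The expected outcome is a number 4 percentage points higher from compound 3 to compound 4 (within the scatter) in this assay and so no step beyond the scatter is anticipated. The estimated value for compound 4 is 68% (expected range 54% to 81%).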

Compound 4, percent growth inhibition at one concentration: 72%
The estimate for compound 4 lay 4 percentage points below the measured number, within the range that was stated.
By their numbers in this assay, from the lowest: compounds 3, 4, 1 and 2 (each within the scatter of the next, the first and the last beyond it).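

In this assay, the position now has a carbon substituent as well as a halogen and hydrogen, and the new group does not separate compound 4 from either neighbour: the change shows a number 8 percentage points higher from compound 3 to compound 4 (within the scatter), and adding the methyl group to the unsubstituted benzyl compound shows a number 1 percentage points lower from compound 1 to compound 4 (within the scatter). The earlier compounds shown here had compared only chloro with hydrogen on this aromatic carbon, para to a large group; hydrogen, chloro and methyl now all lie within the scatter of one another with the rest of the molecule held constant. At the one concentration tested, this read-out therefore does not distinguish 4-methylbenzyl from 4-chlorobenzyl or from plain benzyl, and nothing at hand offers an explanation for that.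

Going by these compounds, it remains open whether a markedly different group on this carbon, such as an amine, a carboxylic acid or a longer chain like propyl, would stay equally close to these compounds. On these data alone, it is also open whether 4-methylbenzyl would behave the same way alongside the methoxy group that compound 2 carries on its other aromatic ring, or at concentrations other than the single one used here.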